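Chloro for Methoxy on the Aryl Amide of Compound 1

A few compounds are considered here, and "the series" means these few. Any claim that something is new, unique, unknown or untested is made for them only; others in the source may bear on it.

Measured compounds in a functional assay on HepG2 cells (Homo sapiens) for antiproliferative activity, read by MTT assay, with a stated time of 72 h; a lower number here means a stronger inhibitor, a higher number a weaker inhibitor:
- compound 1 `COc1ccc(N2C(=O)COc3ccc(-c4cnc(OC)c(NS(=O)(=O)c5ccc(F)cc5)c4)cc32)cc1`: 13100 nM
- compound 2 `COc1ccc(N2C(=O)COc3ccc(-c4ccc(O)cc4)cc32)cc1`: 10800 nM
- compound 3 `O=C1COc2ccc(-c3cnc4ccccc4c3)cc2N1C1CCCCC1`: only a limit, > 40000 nM

Compound 1 carries the higher of the two numbers reported in this assay, but compound 2 lies so close that the gap between them falls within the usual scatter, so the two cannot be placed in any order. Compound 3 gives no number at all in this assay and is recorded only as a limit. It accounts for (the limit of > 40000 nM in this assay, at which 1 of the 3 values shown sits).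

The step under study leads from compound 1 to compound 4 `COc1ncc(-c2ccc3c(c2)N(c2ccc(Cl)cc2)C(=O)CO3)cc1NS(=O)(=O)c1ccc(F)cc1`. The change is a single one: chloro in place of methoxy on an aromatic carbon. The remainder of the shared core and the sulfonamide-bearing pyridine arm are untouched.

Going by the values given here, no measured pair in this set differs in only one place, so the size of such a swap cannot be read from the data. On that basis no step beyond the scatter is expected from compound 1 to compound 4 in this assay, and compound 4 is estimated at 12000 nM, with a range from 5000 nM to 30000 nM, a step expected as a 1.1-fold lower number from compound 1 to compound 4 (0.04 log units; within the scatter).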

Compound 4, half-maximal inhibitory concentration: 17900 nM
Compound 4: the middle estimate sits 1.5-fold (0.17 log units) below what was measured; the range from low to high includes it.
By their numbers in this assay, from the lowest: compounds 2, 1 and 4 (each within the scatter of the next). At a limit, above all of these: compound 3.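

In this assay the set now holds its first pair of compounds that differ in one place, and chloro in place of methoxy on this aromatic carbon, para to a large group, gives a 1.4-fold higher number from compound 1 to compound 4 (0.14 log units; within the scatter) as the size of the swap. At this place on the shared core, then, the change from 4-methoxyphenyl to 4-chlorophenyl leaves the number within the scatter, even though one heavy atom enters where two leave and a hydrogen-bond acceptor is lost, so compound 1 and compound 4 cannot be placed in any order. Nothing given here accounts for the size of this step, small as it is.

The compounds shown leave open whether a group of another kind on this aromatic carbon, such as an amine, a carboxylic acid or a longer chain, would give a step beyond the scatter. Going by these compounds alone, they also leave open whether the sulfonamide-bearing pyridine arm, untouched in this pair, would respond more strongly to a change, since compound 2 and compound 3 each differ from compound 1 in more than one place and offer no step to read.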